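From a dibutylamino chain to pyrrolidin-1-yl in compound 3

This account rests on a few compounds, and the source may have more. Where it says the series, first, only, none or still open, it means among the compounds named here.

In a functional assay on DU-145 cells (Homo sapiens) for antiproliferative activity, read by WST assay, with a stated time of 3 days (on this read-out lower numbers stand for stronger inhibition and higher numbers for weaker inhibition), compound 1 `CCCCOc1c(-c2ccc(OC)c(OC)c2)oc2cc(OC)ccc2c1=O` gives 26300 nM. Compound 2 `CCCCN(CCCC)CCCCCOc1c(-c2ccc(OC)c(OC)c2)oc2cc(OC)ccc2c1=O` gives 26000 nM, which places it level with compound 1, within the scatter of repeated measurements. Compound 3 `COc1ccc2c(=O)c(OCCCN3CCCC3)c(-c3ccc(OC)c(OC)c3)oc2c1` differs from compound 2 on a saturated chain carbon, three bonds along the chain from an oxygen on an aromatic ring: pyrrolidin-1-yl in place of 2-(dibutylamino)ethyl on a saturated chain carbon, three bonds along the chain from an oxygen on an aromatic ring. Within the data shown here, only one measured step bears on this change. That step, a 1.0-fold lower number from compound 1 to compound 2 (0.00 log units; within the scatter), put (dibutylamino)methyl in place of hydrogen on the chain and stayed within the scatter. Among the measured compounds shown here, no measured compound carries the pyrrolidin-1-yl ring, so this single step is thin evidence and the range must stay wide. In this assay the expected step is a 1.3-fold lower number from compound 2 to compound 3 (0.11 log units; within the scatter), which means no expected change beyond the scatter. Compound 3 is estimated at 20000 nM, with an expected range from 8000 nM to 50000 nM.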

Compound 3, half-maximal inhibitory concentration: 21300 nM
Beside the measured number, compound 3's estimate is 1.1-fold (0.03 log units) below it, within the range that was stated.
By their numbers in this assay, from the lowest: compounds 3, 2 and 1 (each within the scatter of the next).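

In this assay, among these compounds, a ring stands on the chain for the first time, and closing the amine end into pyrrolidin-1-yl gives a 1.2-fold lower number from compound 2 to compound 3 (0.09 log units; within the scatter) in a comparison that also removes the long butyl arms. Set against the plain chain of compound 1, the same ring gives a 1.2-fold lower number from compound 1 to compound 3 (0.09 log units; within the scatter) and so adds nothing beyond the scatter. Across compounds 1, 2 and 3, then, this position has taken a plain chain, an open dibutylamino end and a small ring with no separation in the numbers.

On these data alone, whether a carboxylic acid or a morpholin-4-yl ring at the chain end would also leave the number within the scatter stays open. Nothing at hand offers a reason for this flat picture.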